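Swapping fluoro for cyano on the pyridine of compound 1

The compounds below may be only part of what the source reports. "The series", "measured", "known", "first", "only" and "open" are said of these compounds alone.

Measured compounds:
compound 1 `Fc1ccc(-c2ccc(CSc3nnc(-c4ccc5c(c4)OCCO5)o3)cc2)cn1` — 17000 nM
compound 2 `N#Cc1ccc(-c2ccc(CSc3nnc(-c4ccc5c(c4)OCCO5)o3)cc2)nc1` — 181000 nM
compound 3 `Fc1ccc(-c2ccc(CSc3nnc(-c4ccc5c(c4)OCCO5)o3)cn2)cn1` — 1000 nM

In a physicochemical assay for solubility, read by HPLC, using the shake flask method (a lower number here means a less soluble compound, a higher number a more soluble compound), compound 1 gives 17000 nM, the second highest of the three numbers. Its nearest neighbour is compound 2, which in this assay gives 181000 nM; the furthest is compound 3, which in this assay gives 1000 nM, and both gaps lie beyond the scatter.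

Compound 4 `N#Cc1ccc(-c2ccc(CSc3nnc(-c4ccc5c(c4)OCCO5)o3)cc2)cn1` has not yet been measured. It differs from compound 1 as follows: cyano in place of fluoro on an aromatic carbon. Within the data shown here, only one measured step bears on this change: an 11-fold higher number from compound 1 to compound 2 (1.03 log units; beyond the scatter). Among the measured compounds shown here, that step also moved the ring nitrogen of the pyridine, so it is not a clean match for the exchange of fluoro for cyano alone, but it is the only guide, and it points upward. The expected step in this assay is therefore a 2.9-fold higher number from compound 1 to compound 4 (0.47 log units; beyond the scatter), smaller because an 11-fold higher number from compound 1 to compound 2 (1.03 log units; beyond the scatter) included the moved ring nitrogen that is absent here, yet still expected to be beyond the scatter. Compound 4 is expected to give 50000 nM, with a range from 15000 nM to 170000 nM.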

Compound 4, solubility: 50000 nM
Compound 4: middle estimate and measured number agree at the digits printed; measured number inside the range.
By their numbers in this assay, from the lowest: compound 3; then compound 1; then compound 4; then compound 2.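

With the ring nitrogen left where it stands, the change from 6-fluoropyridin-3-yl to 6-cyanopyridin-3-yl can now be read alone: in this assay, it gives a 2.9-fold higher number from compound 1 to compound 4 (0.47 log units; beyond the scatter), so cyano in place of fluoro on this carbon, next to the ring nitrogen, is enough by itself to move the number upward beyond the scatter. The second new step, a 3.6-fold lower number from compound 2 to compound 4 (0.56 log units; beyond the scatter), keeps the cyano group but replaces 5-cyanopyridin-2-yl with 6-cyanopyridin-3-yl, showing that the arrangement of the cyanopyridine also matters and that the earlier step, an 11-fold higher number from compound 1 to compound 2 (1.03 log units; beyond the scatter), did not reflect the exchange of fluoro for cyano alone. No measurement offered here gives a reason for either step.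

From the compounds shown here alone, whether an amine, a methoxy group or a carboxylic acid on this same carbon would give a number above or below that of the cyano group remains open. Also open, going by these compounds, is whether cyano in place of fluoro would produce a similar step on the core of compound 3, whose central ring differs from that of compound 1.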